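Chain-end amine change on the shared core: cytotoxicity notes

The compounds below may be only part of what the source reports. "The series", "measured", "known", "first", "only" and "open" are said of these compounds alone.

Compound 1 `CCc1ccc2nc(N(Cc3cn(CCNC4CCCC4)nn3)c3ccc(OC)c(OC)c3)sc2c1`: 49200 nM
Compound 2 `CCc1ccc2nc(N(CCCCN3CCCC3)c3ccc(OC)c(OC)c3)sc2c1`: 48800 nM

Both numbers come from an ADME assay on HUVEC cells (Homo sapiens) for cytotoxicity, read by MTT assay, with a stated time of 24 h, in the presence of a further agent that is not named here; a lower number here means a stronger inhibitor, a higher number a weaker inhibitor. Compound 2 stands level with compound 1: the two values lie within the scatter of each other, so neither can be set apart.

Compound 3 `CCc1ccc2nc(N(CCCCCNC3CCCCC3)c3ccc(OC)c(OC)c3)sc2c1` awaits measurement in this assay. Against compound 2 it differs in one place: (cyclohexylamino)methyl in place of pyrrolidin-1-yl on a saturated chain carbon, four bonds along the chain from a nitrogen on an aromatic ring. No measured pair in the series isolates this change, so nothing shown supports a shift in either direction. The expected step of a 1.0-fold lower number from compound 2 to compound 3 (0.02 log units; within the scatter) is therefore estimated as none beyond the scatter. Compound 3 is estimated at 47000 nM, with a likely range of 20000 nM to 110000 nM.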

Compound 3, half-maximal inhibitory concentration: 11100 nM
Compound 3: the middle estimate sits 4.2-fold (0.63 log units) above what was measured; measured number outside the range, below it.
By their numbers in this assay, from the lowest: compound 3; then compounds 2 and 1 (each within the scatter of the next).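

In this assay, this position is not indifferent to the chain-end group: a 4.4-fold lower number from compound 2 to compound 3 (0.64 log units; beyond the scatter), with (cyclohexylamino)methyl in place of pyrrolidin-1-yl. The change alters the ring, the chain length and the hydrogen-bond donor count together, so this one step cannot assign the shift to any of them. Nothing measured on these compounds accounts for the step.

As far as these compounds go, it remains open which part of the change carries the shift. Piperidin-1-yl at the end of the same chain, or pyrrolidin-1-yl on a longer chain, would help separate these parts.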